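This account rests on a few compounds, and the source may have more. Where it says the series, first, only, none or still open, it means among the compounds named here.

Among the measured compounds shown here, compound 1 `CCCN(C[C@H]1Cc2c(cccc2N2CCNCC2)CN1)[C@H]1CCCc2cccnc21` stands highest of the three numbers so far: in an ADME assay on microsomes from liver (Mus musculus) for metabolic stability, read by LC-MS, with a stated time of 10 min (a lower number here means that less of the compound is left, a higher number that more of the compound is left), compound 1 gives 87.4%. Compound 2 `CN(C[C@H]1Cc2c(cccc2N2CCN(C3CC3)CC2)CN1)[C@H]1CCCc2cccnc21` gives 7% in this assay, and compound 3 `CCN1CCN(c2cccc3c2C[C@H](CN(C)[C@H]2CCCc4cccnc42)NC3)CC1` gives 18.8%. For the measured compounds named here, the one measured step, a number 11.8 percentage points higher from compound 2 to compound 3 (beyond the scatter), concerns an amine nitrogen in a ring and not the position now changed. Going by the values given here, compound 4 `CC(C)N(C[C@H]1Cc2c(cccc2N2CCNCC2)CN1)[C@H]1CCCc2cccnc21` differs from compound 1 only in isopropyl in place of propyl on an amine nitrogen; no measured step covers this change, so the expectation rests on compound 1 alone. The step is expected to lie within the usual scatter, with a number 0.4 percentage points lower from compound 1 to compound 4 (within the scatter) as the estimated size and no direction claimed. Compound 4 is accordingly estimated at 87%, between 68% and 97%.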

Compound 4, percent of the compound remaining: 91%
Compound 4: the middle estimate sits 4 percentage points below what was measured, and the stated range covers the measured number.
By their numbers in this assay, from the lowest: compound 2; then compound 3; then compounds 1 and 4 (each within the scatter of the next).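

Isopropyl in place of propyl on an amine nitrogen gives a number 3.6 percentage points higher from compound 1 to compound 4 (within the scatter) in this assay. Among the compounds shown here, this is the first step read at this position, and exchanging these two groups, each with 3 carbon atoms, leaves the read-out within the scatter on the core of compound 1. No supporting data bear on this result. Open, as far as these compounds go, is how a longer chain such as butyl, or a ring such as cyclobutyl, would read on this same nitrogen. From the compounds shown here alone, a carboxylic acid carried on a chain there also remains open.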